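The source may report more compounds than this note shows. Statements on the series, on what has been measured and on what is new or still open speak of the compounds shown alone.

Working notes on the series. Two compounds have numbers in a functional assay on Jurkat cells (Homo sapiens) for inhibition; a higher number here means a weaker inhibitor, a lower number a stronger inhibitor. Compound 1 `CCOC(=O)c1cnc(NN2C(=O)C=C(C)C2=O)nc1C1CC1` gives 1500 nM. Compound 2 `CCc1nc(NN2C(=O)C=C(C)C2=O)ncc1C(=O)c1ccccc1` gives 650 nM, the lowest of the two numbers; its gap to compound 1 lies beyond the scatter. Compound 3 `CCc1nc(NN2C(=O)C=C(C)C2=O)ncc1C#N` is not yet measured. It differs from compound 2 by cyano in place of benzoyl on an aromatic carbon. Among the measured compounds shown here, no measured pair shows this change, so the size of the step is open; an upward step from compound 2 to compound 3 of a 2.3-fold higher number from compound 2 to compound 3 (0.36 log units; beyond the scatter) is expected, possibly beyond the scatter. Compound 3 is estimated at 1500 nM, within 500 nM to 4500 nM.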

Compound 3, half-maximal inhibitory concentration: 1100 nM
The estimate for compound 3 lay 1.4-fold (0.13 log units) above the measured number; the range from low to high includes it.
By their numbers in this assay, from the lowest: compounds 2, 3 and 1 (each within the scatter of the next, the first and the last beyond it).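

At the aromatic carbon ortho to an ethyl group, cyano in place of benzoyl gives, in this assay, a 1.7-fold higher number from compound 2 to compound 3 (0.23 log units; within the scatter). This position therefore accepts both benzoyl, with 8 heavy atoms and a six-membered aromatic ring, and cyano, with 2 heavy atoms and no ring, without a step beyond the scatter. Nothing available on these compounds bears on the reason for this result.

On these data alone, how a carboxylic acid or an amine at this carbon would read remains open. So does the effect of replacing the ethyl group with a longer chain while keeping cyano.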